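This account rests on a few compounds, and the source may have more. Where it says the series, first, only, none or still open, it means among the compounds named here.

In a functional assay on Huh-7 cells (Homo sapiens) for antiproliferative activity, with a stated time of 48 h (on this read-out higher numbers stand for weaker inhibition and lower numbers for stronger inhibition), compound 1 (`CCN(CC)c1ccc(-c2cccc(C(F)(F)F)c2)nn1`) gives > 25000 nM as a limit of the assay, not a number. Compound 2 (`CCN(CC)c1ccc(-c2cccc(C#N)c2)nn1`) gives > 25000 nM as a limit too. Compound 3 (`CCN(CC)c1ccc(-c2ccc(C#N)cc2)nn1`) gives > 25000 nM as a limit as well. The evidence so far is the limit of > 25000 nM in this assay, at which 3 of the 3 values shown sit, and nothing more. Compound 4 (`CCN(CC)c1ccc(-c2ccc(C(=O)OC)cc2)nn1`) differs from compound 3 by one change (methoxycarbonyl in place of cyano on an aromatic carbon), methoxycarbonyl in place of cyano on an aromatic carbon. Within the data shown here, the only measured step (a step that the two limits leave unreadable from compound 1 to compound 2) also swaps a group on an aromatic carbon, but it offers no size to carry over. Because compound 3 gives > 25000 nM as a limit, no step beyond the scatter is expected in this assay in either direction. In numbers, the expected step is a step that the limit leaves unreadable from compound 3 to compound 4 and no larger. Compound 4 is expected near 30000 nM with an estimated range from 12000 nM to 60000 nM for its measurement.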

Compound 4, half-maximal inhibitory concentration: 90 nM
The estimate for compound 4 lay 330-fold (2.52 log units) above the measured number; measured number outside the range, below it.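

In this assay, the group on this aromatic carbon, para to a large group, turns out to matter greatly: methoxycarbonyl in place of cyano gives an at least 270-fold lower number from compound 3 to compound 4 (2.44 log units; beyond the scatter). Among these compounds, compound 4 is thus the first compound here with an actual number, and the other steps cannot be read: the limit of > 25000 nM in this assay, at which 3 of the 4 values shown sit. So the shared core can inhibit strongly in this assay when this carbon carries the right group. Still open, going by these compounds, is which part of methoxycarbonyl matters. A carboxylic acid or an amide on this same carbon would help to separate the carbonyl from the methyl ester.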